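The source may report more compounds than this note shows. Statements on the series, on what has been measured and on what is new or still open speak of the compounds shown alone.

Compound 1 `O=C(Nc1cccc(-n2cc(-c3ccncc3)c(-c3ccc(Cl)c(O)c3)n2)c1)Nc1cccc(C(F)(F)F)c1` was examined in a functional assay on SK-MEL-2 cells (Homo sapiens) for inhibition, read by sulforhodamine B assay, with a stated time of 48 h; on this read-out higher numbers stand for lower toxicity in this test and lower numbers for higher toxicity in this test. In this assay compound 1 gives only a limit, > 32500 nM, not a number. Two close relatives do give numbers. Compound 2 `COc1cc(-c2nn(-c3cccc(NC(=O)Nc4cccc(C(F)(F)F)c4)c3)cc2-c2ccncc2)ccc1Cl` carries a methyl on the ring oxygen, and in this assay compound 2 gives 3960 nM; the step is an at least 8.2-fold lower number from compound 1 to compound 2 (0.91 log units; beyond the scatter). Compound 3 `O=C(Nc1cccc(-n2cc(-c3ccncc3)c(-c3ccc(Cl)c(O)c3)n2)c1)Nc1cc(C(F)(F)F)cc(C(F)(F)F)c1` carries a second trifluoromethyl group, and in this assay compound 3 gives 14100 nM; the step is an at least 2.3-fold lower number from compound 1 to compound 3 (0.36 log units; beyond the scatter). Both changes pushed the number down from the ceiling set by the limit of > 32500 nM in this assay, at which 1 of the 3 values shown sits, that is, toward more toxicity in this test.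

Compound 4 `O=C(Nc1cccc(-n2cc(-c3ccncc3)c(-c3ccc(Cl)c(O)c3)n2)c1)Nc1ccc(Cl)c(C(F)(F)F)c1` has not yet been measured. It differs from compound 1 by chloro in place of hydrogen on an aromatic carbon. The nearest measured comparison is the step from compound 1 to compound 3, which also added a group to the ring that already bears the trifluoromethyl; that step was an at least 2.3-fold lower number from compound 1 to compound 3 (0.36 log units; beyond the scatter). A downward shift of about the same modest size is expected for compound 4, namely an at least 3.2-fold lower number from compound 1 to compound 4 (0.51 log units; beyond the scatter). Compound 4 is therefore estimated at 10000 nM, with a likely range from 3000 nM to 32500 nM, while a result reported only as a limit remains possible.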

Compound 4, concentration lethal to 50% of the cells: 5840 nM
The estimate for compound 4 lay 1.7-fold (0.23 log units) above the measured number; the range from low to high includes it.
By their numbers in this assay, from the lowest: compounds 2 and 4 (each within the scatter of the next); then compound 3. At a limit, above all of these: compound 1.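

In this assay, the change from 3-(trifluoromethyl)phenyl to 4-chloro-3-(trifluoromethyl)phenyl places a chloro of 1 heavy atom ortho to a trifluoromethyl group and para to a large group, and it gives an at least 5.5-fold lower number from compound 1 to compound 4 (0.74 log units; beyond the scatter), which points toward more toxicity in this test. Until now, the only change shown on this ring was the added trifluoromethyl group of compound 3, a group of 4 heavy atoms, so compound 4 shows that a chloro of 1 heavy atom at this place can also move the number beyond the scatter. The true size of the step stays unknown, and it can be read only as a minimum, because compound 1 gives no number here: the limit of > 32500 nM in this assay, at which 1 of the 4 values shown sits.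

The compounds shown leave open whether this shift belongs to chloro in particular or would also follow from another group at this place, such as fluoro, methyl, an amine or a carboxylic acid. They also leave open whether chloro at this place would have the same effect on a ring without the trifluoromethyl group.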